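The source may hold more compounds than are shown below. What is called first, only, known or untested is meant among the compounds shown, and "the series" means these compounds.

Of the compounds shown here, three have been measured in a functional assay for inhibition, with Cavia porcellus as the target; on this read-out higher numbers stand for weaker inhibition and lower numbers for stronger inhibition. Compound 1 `N=C(N)c1ccc(C(=O)NCC[C@H]2C(=O)N(CC(=O)O)CCN2C(=O)CNC(=O)c2ccc(C(=N)N)cc2)cc1` gives 190 nM. Compound 2 `N=C(N)Nc1ccc(C(=O)NCCC[C@H]2C(=O)N(CC(=O)O)CCN2C(=O)CNC(=O)c2ccc(C(=N)N)cc2)cc1` gives 19 nM. Compound 3 `N=C(N)c1ccc(C(=O)NCC(=O)N2CCN(CC(=O)O)C(=O)[C@@H]2CCCNC(=O)CCCCN)cc1` gives 210 nM, the highest of the three numbers, although compound 1 lies within the scatter of it and only compound 2 sits clearly lower. Both measured steps end at compound 3: the step of a 1.1-fold higher number from compound 1 to compound 3 (0.04 log units; within the scatter) exchanges an aromatic group for a chain carrying an amine, and the step of an 11-fold higher number from compound 2 to compound 3 (1.04 log units; beyond the scatter) makes a similar exchange at a carbonyl carbon. Compound 4 `N=C(N)c1ccc(C(=O)NCC(=O)N2CCN(CC(=O)O)C(=O)[C@@H]2CCCNC(=O)CCCCCN)cc1` differs from compound 3 by aminomethyl in place of amino on a saturated chain carbon, four bonds along the chain from a carbonyl carbon, so the chain grows by one carbon while everything else stays. Neither measured step lengthens a chain; both swap a ring for a chain, so they bear only loosely on this change. Compound 1 and compound 2 differ in chain length and in another group at once, so their two values cannot separate the two effects. A step in this assay of no change at the digits printed from compound 3 to compound 4 (within the scatter) is therefore expected, within the scatter. Compound 4 is estimated at 210 nM, with a range from 80 nM to 550 nM.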

Compound 4, half-maximal inhibitory concentration: 160 nM
Estimate against measurement, compound 4: 1.3-fold (0.12 log units) above; low and high end bracket the measured number.
By their numbers in this assay, from the lowest: compound 2; then compounds 4, 1 and 3 (each within the scatter of the next).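

Lengthening the chain by one carbon, with aminomethyl in place of amino, gives a 1.3-fold lower number from compound 3 to compound 4 (0.12 log units; within the scatter) in this assay, so at this position the two chain lengths cannot be told apart. The longer chain also leaves the earlier picture intact: exchanging the aromatic group for it gives a 1.2-fold lower number from compound 1 to compound 4 (0.07 log units; within the scatter), while the other exchange of a ring for a chain still stands clear of the scatter, at an 8.4-fold higher number from compound 2 to compound 4 (0.93 log units; beyond the scatter). No measurement here explains these results.

With only two neighbouring chain lengths shown, it remains open whether a longer chain would eventually move the number or narrow the gap to the ring-bearing group. On these data alone, it also remains open whether the amine at the chain end matters, which a hydroxyl in its place could test.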